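The compounds below may be only part of what the source reports. "The series", "measured", "known", "first", "only" and "open" are said of these compounds alone.

Of the compounds shown here, three of a shared urea-pyrazole series have been tested in a functional assay on SF-268 cells (Homo sapiens) for inhibition, read by sulforhodamine B assay, with a stated time of 48 h; on this read-out higher numbers stand for weaker inhibition of growth and lower numbers for stronger inhibition of growth. Compound 1, `COc1cc(-c2nn(-c3cccc(NC(=O)Nc4cc(C(F)(F)F)cc(C(F)(F)F)c4)c3)cc2-c2ccncc2)ccc1Cl`, gives 978 nM in this assay. Compound 2, `O=C(Nc1cccc(-n2cc(-c3ccncc3)c(-c3ccc(Cl)c(O)c3)n2)c1)Nc1cc(C(F)(F)F)cc(C(F)(F)F)c1`, differs from compound 1 by hydrogen in place of methyl on an oxygen on an aromatic ring, and in this assay compound 2 gives 846 nM. That single change made a 1.2-fold lower number from compound 1 to compound 2 (0.06 log units; within the scatter), so the two values cannot be told apart with confidence. Compound 3, `COc1cc(-c2nn(-c3cccc(NC(=O)Nc4ccc(Cl)c(C(F)(F)F)c4)c3)cc2-c2ccncc2)ccc1Cl`, carries a different urea end from compound 1; the difference between the two cores is not broken down here. In this assay compound 3 gives 1460 nM, and that value sits within the scatter of both compound 1 and compound 2, so no ordering among the three can be claimed.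

Compound 4, `O=C(Nc1cccc(-n2cc(-c3ccncc3)c(-c3ccc(Cl)c(O)c3)n2)c1)Nc1ccc(Cl)c(C(F)(F)F)c1`, has not yet been measured. It differs from compound 3 by hydrogen in place of methyl on an oxygen on an aromatic ring, and the surroundings of that place are the same as in the step from compound 1 to compound 2, so it is the same change made on the core of compound 3. Because the measured example of this change produced a 1.2-fold lower number from compound 1 to compound 2 (0.06 log units; within the scatter), the expectation is that compound 4 will show a step of about a 1.2-fold lower number from compound 3 to compound 4 (0.09 log units; within the scatter), again too small to count as a real shift. On that basis compound 4 is estimated at 1200 nM in this assay, with a likely range from 600 nM to 2500 nM.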

Compound 4, concentration for 50% growth inhibition: 1060 nM
For compound 4 the middle estimate is 1.1-fold (0.05 log units) above the measured one; the range from low to high includes it.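

Replacing methoxy with hydroxy on the core of compound 3 gave a 1.4-fold lower number from compound 3 to compound 4 (0.14 log units; within the scatter). Set beside the earlier example, the change behaves alike on both cores in this assay: the same change on two cores in this assay, a 1.2-fold lower number (0.06 log units; within the scatter) from compound 1 to compound 2 and a 1.4-fold lower number (0.14 log units; within the scatter) from compound 3 to compound 4, 1.2-fold (0.08 log units) apart, within the scatter of two such steps

The swap therefore carries from one urea end to the other in the sense that on both cores it leaves the number within the usual scatter, but this is agreement between two small steps, not a real gain in growth inhibition passed from one core to the next. Among the compounds shown here, it does not show that the swap would stay this quiet on cores that differ in any other place, and with only two examples it supports no general rule for the series.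

What the compounds shown leave open is whether a different group at this oxygen on the aromatic ring, such as an ethoxy chain, or an amine in place of the hydroxy, would move the number beyond the scatter. Also open, from the compounds shown here alone, is whether the methoxy to hydroxy swap stays this small on a urea end carrying another group, such as a nitrile, or in a read-out other than this assay.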